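Anilide series: methylsulfanyl analogue expected at assay limit

The compounds below may be only part of what the source reports. "The series", "measured", "known", "first", "only" and "open" are said of these compounds alone.

Measured compounds:
compound 1 `Cc1ccc(NC(=O)c2cccc(/C=C3\CC(=O)N(c4ccccc4)C3=O)c2)cc1` — > 100000 nM
compound 2 `COc1ccc(NC(=O)c2cccc(/C=C3\CC(=O)N(c4ccc(C)cc4)C3=O)c2)cc1` — > 100000 nM

In an ADME assay on HCT-116 cells (Homo sapiens) for cytotoxicity, read by MTT assay, with a stated time of 72 h (on this read-out higher numbers stand for weaker inhibition and lower numbers for stronger inhibition), compound 1 gives > 100000 nM, which is a limit of the assay and not a number. Compound 2 gives > 100000 nM in this assay, likewise a limit. For the measured compounds named here, compound 1 thus sits at the limit of > 100000 nM in this assay, at which 2 of the 2 values shown sit, and no step between measured compounds is available around it. Compound 3 `CSc1cccc(NC(=O)c2cccc(/C=C3\CC(=O)N(c4ccccc4)C3=O)c2)c1` carries 3-(methylsulfanyl)phenyl in place of 4-methylphenyl on an amide-type nitrogen. Nothing measured bears on this change, so no shift beyond the usual scatter is expected. The estimated step of a number no higher from compound 1 to compound 3 (the limit leaves the size open) is therefore taken as none. Compound 3 is expected near 100000 nM, within 30000 nM to 300000 nM, and most probably reported only as a limit.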

Compound 3, half-maximal inhibitory concentration: 65200 nM
Beside the measured number, compound 3's estimate is 1.5-fold (0.19 log units) above it; the range from low to high includes it.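

Replacing 4-methylphenyl with 3-(methylsulfanyl)phenyl on an amide-type nitrogen gives compound 3, the only compound shown with a measured number rather than a limit: the limit of > 100000 nM in this assay, at which 2 of the 3 values shown sit. Going by these compounds, the change gives an at least 1.5-fold lower number from compound 1 to compound 3 (0.18 log units; that floor lies within the scatter), so activity in this assay cannot be said to have changed beyond the scatter, and the true size of the step stays unknown.

The compounds shown do not separate the effect of the methylsulfanyl group from that of its ring position, which 4-(methylsulfanyl)phenyl would address. On these data alone, how an amine or a carboxylic acid at this position would read also remains open.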